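A few compounds are considered here, and "the series" means these few. Any claim that something is new, unique, unknown or untested is made for them only; others in the source may bear on it.

Compound 1 `Cn1cc(C2=C(c3nn(CCn4ccnc4)c4ncccc34)C(=O)NC2=O)c2ccccc21` is the parent of this small set. In a functional assay on A549 cells (Homo sapiens) for antiproliferative activity, read by MTT assay, with a stated time of 48 h (a lower number here means a stronger inhibitor, a higher number a weaker inhibitor), compound 1 gives only a limit, > 100000 nM. Compound 3 `CN1CCN(CCCn2nc(C3=C(c4cn(C)c5ccccc45)C(=O)NC3=O)c3cccnc32)CC1` likewise gives only a limit in this assay, > 100000 nM. The step that the two limits leave unreadable from compound 1 to compound 3 is thus not readable in size. Compound 2 `Cn1cc(C2=C(c3nn(CCCN4CCCCC4)c4ncccc34)C(=O)N(c3ccc(Cl)cc3)C2=O)c2ccccc21` gives 28700 nM in this assay. Compound 4 `Cn1cc(C2=C(c3nn(CCCN4CCCCC4)c4ncccc34)C(=O)NC2=O)c2ccccc21` differs from compound 1 by (piperidin-1-yl)methyl in place of 1H-imidazol-1-yl on a saturated chain carbon, two bonds along the chain from an aromatic nitrogen. Within the data shown here, compound 2 carries the same chain, but no single-point step links it to compound 4, so its value shows only that this chain appears in a measured compound. Among the measured compounds shown here, no measured step bears on the change with a readable size, and compound 1 sits at the limit of > 100000 nM in this assay, at which 2 of the 3 values shown sit. Compound 4 is expected to stay near that limit, an estimated step of an at least 1.2-fold lower number from compound 1 to compound 4 (0.09 log units; that floor lies within the scatter). The estimate for compound 4 is 80000 nM, within 20000 nM to 300000 nM.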

Compound 4, half-maximal inhibitory concentration: > 100000 nM
Compound 4 gave a limit, no number (the forecaster's own chance of this, stated with the estimate: 55%); middle value at least 1.2-fold (0.09 log units) from the limit.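

Compound 4 gives no readable size for the chain change: the steps to it from compound 1 and from compound 3 cannot be read, since both ends of each are limits. With the 3-(piperidin-1-yl)propyl chain held constant, hydrogen in place of 4-chlorophenyl on an amide-type nitrogen in a ring gives an at least 3.4-fold higher number from compound 2 to compound 4 (0.54 log units; beyond the scatter) in this assay. A readable value occurs only with 4-chlorophenyl on that nitrogen, and the rest of the set gathers at one reading: the limit of > 100000 nM in this assay, at which 3 of the 4 values shown sit.

From the compounds shown here alone, whether 4-chlorophenyl gives a readable value with the 2-(1H-imidazol-1-yl)ethyl chain or the 4-methylpiperazin-1-yl chain remains open. Also open, going by these compounds, is what a methyl or benzyl group on that nitrogen would give.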